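Adding a chloro group to compound 2

This account rests on a few compounds, and the source may have more. Where it says the series, first, only, none or still open, it means among the compounds named here.

Of the compounds shown here, two have been measured in a functional assay on the whole organism (strain albino) for inhibition, with Rattus norvegicus as the target, read by paw edema, with stated times of 1 h and 0.5 h, at a dose of 100 mg/kg by the oral route; a higher number here means more inhibition at the dose given (going by the name of the read-out), a lower number less inhibition. Compound 1 `N#Cc1c(-c2ccc(Cl)cc2)nc(SCC(=O)Nn2c(COc3ccc(Cl)cc3Cl)nc3ccccc3c2=O)[nH]c1=O` gives 61.5% in this assay. Compound 2 `Cn1c(SCC(=O)Nn2c(COc3ccc(Cl)cc3Cl)nc3ccccc3c2=O)nc(-c2ccccc2)c(C#N)c1=O` gives 51.9% in this assay, and on these two numbers compound 2 cannot be told apart from compound 1, since the gap between them lies within the usual scatter of repeated measurements. Among the measured compounds shown here, no single-point step between measured compounds is available. Compound 1 and compound 2 differ in more than one place.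

Compound 3 `Cn1c(SCC(=O)Nn2c(COc3ccc(Cl)cc3Cl)nc3ccccc3c2=O)nc(-c2ccc(Cl)cc2)c(C#N)c1=O` has not yet been measured in this assay. The change from compound 2 to compound 3 is chloro in place of hydrogen on an aromatic carbon. With nothing in the measured pair to show what this change alone does, no shift beyond the scatter is expected; the step of a number 3.1 percentage points higher from compound 2 to compound 3 (within the scatter) is estimated to be small. Compound 3 is therefore expected to give about 55% in this assay, within a range of 40% to 70%.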

Compound 3, a percentage reported as inhibition, in the whole organism at one dose (the size of the read-out at that dose, not a potency): 80.8%
Beside the measured number, compound 3's estimate is 25.8 percentage points below it; measured number outside the range, above it.
By their numbers in this assay, from the lowest: compounds 2 and 1 (each within the scatter of the next); then compound 3.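

In this assay, among the compounds shown here, the change from phenyl to 4-chlorophenyl gives the first reading of a single change at this position, a number 28.9 percentage points higher from compound 2 to compound 3 (beyond the scatter), so chloro in place of hydrogen on this aromatic carbon, para to a large group, makes a difference beyond the scatter when the aromatic nitrogen carries methyl. With 4-chlorophenyl held in place, methyl in place of hydrogen on that aromatic nitrogen also makes a difference beyond the scatter, a number 19.3 percentage points higher from compound 1 to compound 3 (beyond the scatter), and compound 3 stands above both other compounds. Nothing at hand accounts for the size of either step.

The compounds shown leave open whether a fluoro or methoxy group at the same place would match chloro, and whether an ethyl group on the aromatic nitrogen would match methyl. Going by these compounds, whether the chloro step also holds with hydrogen on that nitrogen stays open too.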